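A few compounds are considered here, and "the series" means these few. Any claim that something is new, unique, unknown or untested is made for them only; others in the source may bear on it.

Two compounds have been examined so far. Compound 1, `CNC(=O)[C@@]12C[C@@H]1[C@@H](n1cnc3c(NC)nc(C#Cc4cccnc4)nc31)[C@H](O)[C@@H]2O`, gives 16% in an assay on CHO cells for displacement of a labelled ligand from adenosine receptor A1 (Homo sapiens), read by scintillation counting, with a stated time of 60 min, tested at 10 uM; a higher number here means more inhibition at the concentration tested (going by the name of the read-out), a lower number less inhibition. Compound 2, `CNC(=O)[C@@]12C[C@@H]1[C@@H](n1cnc3c(NC)nc(C#Cc4cc(C)c(C)o4)nc31)[C@H](O)[C@@H]2O`, gives 15% in this assay. Among the measured compounds shown here, the single step between them, a number 1 percentage points lower from compound 1 to compound 2 (within the scatter), changes nothing that the method can resolve, so compound 2 stands level with compound 1: neither number can be called higher or lower with any confidence.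

Compound 3 is `CNC(=O)[C@@]12C[C@@H]1[C@@H](n1cnc3c(NC)nc(C#Cc4ccsc4)nc31)[C@H](O)[C@@H]2O`. Compared with compound 2 it carries thiophen-3-yl in place of 4,5-dimethylfuran-2-yl on a triple-bonded carbon. For the measured compounds named here, the one measured step that bears on this, the exchange of one aromatic ring for another on the same triple-bonded carbon, was a number 1 percentage points lower from compound 1 to compound 2 (within the scatter), a change that stayed within the scatter. With only that to go on, the expected step in this assay is likewise none beyond the scatter, no change at the digits printed from compound 2 to compound 3 (within the scatter). Compound 3 is therefore expected to give about 15% in this assay, with a range from 4% to 30%.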

Compound 3, a percentage reported as inhibition, at one concentration (the size of the read-out at that concentration, not a potency): 11%
The estimate for compound 3 lay 4 percentage points above the measured number; the measured number falls inside the stated range.
By their numbers in this assay, from the lowest: compounds 3, 2 and 1 (each within the scatter of the next).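

Three different aromatic rings have now stood on this triple-bonded carbon, and in this assay the third, thiophen-3-yl, cannot be told apart from the other two: the result is a number 4 percentage points lower from compound 2 to compound 3 (within the scatter) and a number 5 percentage points lower from compound 1 to compound 3 (within the scatter) in the comparison with the pyridin-3-yl ring. Going from the 7 heavy atoms of 4,5-dimethylfuran-2-yl to the 5 of thiophen-3-yl, with sulfur in place of oxygen in the ring, therefore moves the number no further than the method can resolve, and the three rings cannot be ranked. Nothing independent of these readings is available to explain them.

As far as these compounds go, what stays open is whether a group without an aromatic ring at this place, such as a longer alkyl chain or an amine on a short chain, would give a clearly different number. These readings come from one concentration, so they leave potency itself open as well.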